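Weak Amine Oxidase Binders: Predicting a Halogenated Analogue

The source may hold more compounds than are shown below. What is called first, only, known or untested is meant among the compounds shown, and "the series" means these compounds.

Measured so far:
Compound 1 `COc1ccc(CCSc2nc3c(c(=O)n(C)c(=O)n3C)n2C)cc1`: 168000 nM
Compound 2 `Cn1c(=O)c2c(nc([S+]([O-])CCc3ccc(Br)cc3)n2C)n(C)c1=O`: 57300 nM

Both compounds were tested in an assay on microsomes for inhibition of Amine oxidase [flavin-containing] A (Homo sapiens), read by fluorescence and spectrophotometry, with a stated time of 20 min; on this read-out higher numbers stand for weaker inhibition and lower numbers for stronger inhibition. Compound 1 gives 168000 nM, the highest number of the two, and therefore the weaker inhibitor on this read-out. Compound 2 gives 57300 nM, a lower number, and the gap between compound 1 and compound 2 lies beyond the usual scatter of repeated measurements.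

Compound 3 `Cn1c(=O)c2c(nc(SCCCc3cccc(Cl)c3)n2C)n(C)c1=O` shares the core of compound 1 and differs from it in one place: 3-chlorobenzyl in place of 4-methoxyphenyl on a saturated chain carbon, two bonds along the chain from a sulfur. No measured pair tells how exactly this kind of exchange plays out, so the expectation rests on the two numbers shown. Among the measured compounds shown here, compound 2, the only compound bearing a halogen on its aromatic ring, gives the lower number, which points towards a lower number for compound 3 as well, though a step of only modest size, close to the scatter, is expected. The estimate for compound 3 in this assay is 80000 nM, with a likely range from 25000 nM to 250000 nM, meaning an expected step of a 2.1-fold lower number from compound 1 to compound 3 (0.32 log units; beyond the scatter).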

Compound 3, half-maximal inhibitory concentration: 3530 nM
Estimate against measurement, compound 3: 23-fold (1.36 log units) above, and the stated range ends above it.
By their numbers in this assay, from the lowest: compound 3; then compound 2; then compound 1.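

In this assay, putting 3-chlorobenzyl in place of 4-methoxyphenyl on a saturated chain carbon, two bonds along the chain from a sulfur, gives a 48-fold lower number from compound 1 to compound 3 (1.68 log units; beyond the scatter) and so shows that the group at this place has a large bearing on the read-out. The two groups match in heavy-atom count and each holds one six-membered aromatic ring of carbon only, yet they still differ in two ways: chlorine replaces oxygen, and a benzyl group replaces a phenyl group. Nothing at hand explains the size of this step.

Among the compounds shown here, the single exchange leaves open whether the chlorine or the benzyl group matters more, a question that 4-chlorophenyl or 3-methoxybenzyl at the same place could help settle. From the compounds shown here alone, how an amine or a carboxylic acid on the ring would behave also stays open.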